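Compound 4: pyridin-3-yl in place of 2-methylphenyl

This account rests on a few compounds, and the source may have more. Where it says the series, first, only, none or still open, it means among the compounds named here.

For the measured compounds named here, compound 1 `Cc1ccccc1N/C(=N\C#N)N1CCN(C(=O)Nc2ccc(Cl)cc2)C(c2ccccc2)C1` gives 95 nM in a functional assay for antagonist activity at P2X purinoceptor 7 (Rattus norvegicus), read by FLIPR and calcium flux (a higher number here means a weaker inhibitor, a lower number a stronger inhibitor), the lowest of the three numbers so far. Compound 3 `Cc1ccccc1N/C(=N\C#N)N1CCN(C(=O)Nc2ccc(Cl)cc2)C(C(C)C)C1` gives 110 nM in this assay, and the step of a 1.2-fold higher number from compound 1 to compound 3 (0.06 log units; within the scatter) leaves the two indistinguishable. Going by the values given here, compound 2 `Cc1ccccc1N/C(=C/[N+](=O)[O-])N1CCN(C(=O)Nc2ccc(Cl)cc2)C(c2ccccc2)C1` gives 3110 nM in this assay, the number furthest from compound 1, and no single-point step is drawn between these two. Compound 4 `N#C/N=C(\Nc1cccnc1)N1CCN(C(=O)Nc2ccc(Cl)cc2)C(c2ccccc2)C1` carries pyridin-3-yl in place of 2-methylphenyl on an amine nitrogen. Among the compounds with values here, no measured step touches this nitrogen: the one recorded step, a 1.2-fold higher number from compound 1 to compound 3 (0.06 log units; within the scatter), sits on a saturated ring carbon and stayed within the scatter, so it neither supports nor argues against a change here. Within the data shown here, the data show that the core of compound 1 tolerates one exchange of a substituent without a step beyond the scatter, but an exchange of the aromatic ring on the amine nitrogen has no precedent among the measured compounds. Compound 4 is therefore expected to show only a modest step, a 2.6-fold higher number from compound 1 to compound 4 (0.42 log units; beyond the scatter), with the allowance leaning toward a weaker number. The estimate for compound 4 is 250 nM, expected within 80 nM to 800 nM.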

Compound 4, half-maximal inhibitory concentration: 2040 nM
Beside the measured number, compound 4's estimate is 8.2-fold (0.91 log units) below it; the measured number lies above the stated range.
By their numbers in this assay, from the lowest: compounds 1 and 3 (each within the scatter of the next); then compounds 4 and 2 (each within the scatter of the next).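

For the compounds shown here, the amine nitrogen substituent is the first place where a single exchange gives a step beyond the scatter: in this assay, pyridin-3-yl in place of 2-methylphenyl gives a 21-fold higher number from compound 1 to compound 4 (1.33 log units; beyond the scatter). This position therefore behaves differently from the saturated ring carbon, where the exchange of phenyl for isopropyl gave a 1.2-fold higher number from compound 1 to compound 3 (0.06 log units; within the scatter) and stayed within the scatter. No measurement shown here bears on the cause of the larger step.

The exchange removes the methyl group and brings a ring nitrogen in at once, so the compounds shown leave open which of the two carries the step; plain phenyl on this amine nitrogen would separate them. Also open, going by these compounds, is whether the step keeps its size with isopropyl in place of phenyl on the saturated ring carbon.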